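Phenyl to methyl on the amine side chain

The source may report more compounds than this note shows. Statements on the series, on what has been measured and on what is new or still open speak of the compounds shown alone.

Compound 1 `COc1cc2c(cc1C(C)N1CCCC1)C=CC(C)(C)O2` and compound 2 `COc1cc2c(cc1C(C)NCCCc1ccccc1)CCC(C)(C)O2` share a core that differs only in the saturation of the oxygen-containing ring, and both carry a secondary or tertiary amine on the carbon attached to the aromatic ring. In an assay on cell membranes for displacement of a labelled ligand from Sigma non-opioid intracellular receptor 1 (Cavia porcellus), read by scintillation counting (a higher number here means a weaker inhibitor, a lower number a stronger inhibitor), compound 1 gives 19 nM. In this assay compound 2 gives 19 nM, level with compound 1 at the digits shown; the two values lie within the usual scatter, so no order between them is claimed.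

Compound 3 `CCCCNC(C)c1cc2c(cc1OC)OC(C)(C)CC2` has not yet been measured. It differs from compound 2 by methyl in place of phenyl on a saturated chain carbon, three bonds along the chain from an amine nitrogen, so the chain on the amine nitrogen becomes butyl in place of phenylpropyl. For the measured compounds named here, no measured pair in this set covers such a change, so the size of the step cannot be read from the data. The expectation is that losing the aromatic ring on the chain weakens binding by a moderate step, and the step from compound 2 to compound 3 is estimated as a 3.7-fold higher number from compound 2 to compound 3 (0.57 log units; beyond the scatter). Compound 3 is therefore expected to give 70 nM in this assay, within a range of 20 nM to 250 nM.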

Compound 3, inhibition constant: 43 nM
Compound 3: middle estimate off by 1.6-fold (0.21 log units), on the high side, within the range that was stated.
By their numbers in this assay, from the lowest: compounds 1 and 2 (each within the scatter of the next); then compound 3.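

In this assay, for the compounds shown here, methyl in place of phenyl on a saturated chain carbon, three bonds along the chain from an amine nitrogen, gives a 2.3-fold higher number from compound 2 to compound 3 (0.35 log units; beyond the scatter): this is the first measured step at this position, and it is modest but beyond the scatter. The phenyl is therefore not required for binding in this series, since compound 3, with plain butyl on the amine nitrogen, still gives 43 nM, but the aromatic end of the chain does go with the lower number within this single pair. Nothing shown here accounts for the size of this step, and no measurement of any property of the two chains accompanies it.

Open, as far as these compounds go, is whether the loss follows the aromatic ring itself or the six carbons it brings, which cyclohexyl at this place would separate, and whether a longer chain such as hexyl would recover the number of compound 2. Going by these compounds alone, also open is how a hydroxyl or a carboxylic acid at the chain end would read, and compound 1 differs from compound 3 in more than one place, so it gives no step on these questions.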